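A few compounds are considered here, and "the series" means these few. Any claim that something is new, unique, unknown or untested is made for them only; others in the source may bear on it.

Measured in a functional assay on B16 cells (Mus musculus) for cytotoxicity, read by CCK-8 assay, with a stated time of 24 h; on this read-out lower numbers stand for stronger inhibition and higher numbers for weaker inhibition:
Compound 1 `COc1ccccc1Oc1c(N)nc(Cc2ccccc2)nc1OCCO`: 47400 nM
Compound 2 `COc1ccc(-c2nc(N)c(Oc3ccccc3OC)c(OCCO)n2)cc1`: 18100 nM
Compound 3 `COc1ccccc1Oc1c(N)nc(-c2ccccc2F)nc1OCCO`: 11800 nM

Compound 3 clearly improves on the first compound, as shown by a 4.0-fold lower number from compound 1 to compound 3 (0.60 log units; beyond the scatter). It cannot be separated from the second, as shown by a 1.5-fold lower number from compound 2 to compound 3 (0.19 log units; within the scatter). Compound 4 `COc1ccccc1Oc1c(N)nc(-c2cccc(I)c2)nc1OCCO` has 3-iodophenyl in place of 2-fluorophenyl on an aromatic carbon. For the measured compounds named here, the closest precedent is the exchange of one substituted phenyl group for another, which gave that small step to compound 3. The larger steps, a 2.6-fold lower number from compound 1 to compound 2 (0.42 log units; beyond the scatter) and the one above, both replaced benzyl, which is not what happens here. Going by the values given here, no measured compound carries iodine, so the expectation is uncertain, and no step beyond the scatter is expected in this assay. The estimated step is a 1.1-fold lower number from compound 3 to compound 4 (0.03 log units; within the scatter). Compound 4 is expected at 11000 nM, within an estimated range of 5000 nM to 25000 nM.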

Compound 4, half-maximal inhibitory concentration: 20300 nM
Compound 4: the middle estimate sits 1.8-fold (0.27 log units) below what was measured; the range from low to high includes it.
By their numbers in this assay, from the lowest: compounds 3, 2 and 4 (each within the scatter of the next); then compound 1.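

Read in this assay, the step to 3-iodophenyl is a 1.7-fold higher number from compound 3 to compound 4 (0.24 log units; within the scatter) and the exchange for 4-methoxyphenyl is a 1.1-fold higher number from compound 2 to compound 4 (0.05 log units; within the scatter), so three quite different substituted phenyl groups cannot be told apart at this position. Only the exchange for benzyl stands out, with a 2.3-fold lower number from compound 1 to compound 4 (0.37 log units; beyond the scatter), which goes the same way as the steps from compound 1 to the other two phenyl compounds. Nothing available explains these steps.

Still open, on these data alone, is whether an amine or a carboxylic acid on the phenyl ring would give a clearer step. The same holds for a single substituent moved around that ring.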